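The source may report more compounds than this note shows. Statements on the series, on what has been measured and on what is new or still open speak of the compounds shown alone.

Compound 1 `N#Cc1ccc(-c2cc(-c3ccc(C(N)=O)cc3)cc(-c3ccco3)n2)cc1` and compound 2 `NC(=O)c1ccc(-c2cc(-c3ccc(-c4nccs4)cc3)nc(-c3ccco3)c2)cc1` share a common core and were both tested in a physicochemical assay for solubility, at pH 6; on this read-out higher numbers stand for higher solubility and lower numbers for lower solubility. In this assay compound 1 gives 10000 nM, the lower of the two numbers, and compound 2 gives 125000 nM. Among the compounds with values here, the one measured step, a 13-fold higher number from compound 1 to compound 2 (1.10 log units; beyond the scatter), comes from the change of a cyano group to a 1,3-thiazol-2-yl group on an aromatic carbon.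

Compound 3 `N#Cc1ccc(-c2cc(-c3ccc(C(N)=O)cc3)cc(-c3cccc(F)c3)n2)cc1` has not yet been measured in this assay. It differs from compound 1 by 3-fluorophenyl in place of furan-2-yl on an aromatic carbon. Within the data shown here, this change sits at a different place from the one in the measured step, so no measured step bears directly on it; the step from compound 1 to compound 2 only shows that a change elsewhere on the same core can move the number by a large amount. With nothing measured at the place of this change, the expectation for compound 3 rests on the value of compound 1, 10000 nM, and the expected step is a 1.3-fold lower number from compound 1 to compound 3 (0.10 log units; within the scatter), which lies within the scatter. Compound 3 is therefore estimated at 8000 nM, with a range from 1500 nM to 40000 nM.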

Compound 3, solubility: 2000 nM
Beside the measured number, compound 3's estimate is 4.0-fold (0.60 log units) above it, within the range that was stated.
By their numbers in this assay, from the lowest: compound 3; then compound 1; then compound 2.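

Within the data shown here, the place next to the ring nitrogen, which held furan-2-yl in the earlier compounds, now has a measured step of its own in this assay: 3-fluorophenyl in place of furan-2-yl gives a 5.0-fold lower number from compound 1 to compound 3 (0.70 log units; beyond the scatter). This shows that the number responds to a change at this place as well as at the place of the cyano group, where the change to 1,3-thiazol-2-yl gave a 13-fold higher number from compound 1 to compound 2 (1.10 log units; beyond the scatter), and here the number falls rather than rises. The entering group has a six-membered aromatic ring of carbon only where the leaving group has a five-membered aromatic ring with 1 hetero atom, but no measurement shown ties the step to any one of these differences.

Ring size, the loss of the ring oxygen and the arrival of the fluorine all change together, so the compounds shown leave open which of them goes with the lower number, and an unsubstituted phenyl group at this place would be needed to separate them. Also open, on these data alone, are how the number would respond to an amine or a carboxylic acid on this ring, and whether the step would carry over to the core of compound 2.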